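Furan for Thiophene on Two Nucleoside Cores

This account rests on a few compounds, and the source may have more. Where it says the series, first, only, none or still open, it means among the compounds named here.

Compound 1 `CSc1ncnc2c1c(-c1ccoc1)cn2[C@@H]1O[C@H](CO)[C@@H](O)[C@H]1O` and compound 2 `CSc1ncnc2c1c(-c1cccs1)cn2[C@@H]1O[C@H](CO)[C@@H](O)[C@H]1O` share one core and differ in a single place. In a functional assay on HCT-116 cells (Homo sapiens), read by MTT assay, with a stated time of 72 h (a higher number here means a weaker inhibitor, a lower number a stronger inhibitor), compound 1 gives 100 nM. Compound 2 reaches only the limit of the assay, > 20000 nM. The change furan-3-yl in place of thiophen-2-yl on an aromatic carbon thus produces an at least 200-fold lower number from compound 2 to compound 1 (2.30 log units; beyond the scatter), and this size is a floor because compound 2 sits at the limit of > 20000 nM in this assay, at which 2 of the 3 values shown sit. Compound 3 `Nc1nc(N)c2c(-c3cccs3)cn([C@@H]3O[C@H](CO)[C@@H](O)[C@H]3O)c2n1` carries the thiophen-2-yl group on another core; how the two cores differ is not broken down here. In this assay compound 3 also gives only a limit, > 20000 nM. Compound 4 `Nc1nc(N)c2c(-c3ccoc3)cn([C@@H]3O[C@H](CO)[C@@H](O)[C@H]3O)c2n1` applies the same change, (furan-3-yl in place of thiophen-2-yl on an aromatic carbon), to the core of compound 3. Among the compounds with values here, no measured pair shows how that core responds to the furan, so compound 4 is expected to give 2000 nM, estimated to lie between 100 nM and 20000 nM. That estimate means an expected at least 10-fold lower number from compound 3 to compound 4 (1.00 log units; beyond the scatter), resting on the measured at least 200-fold lower number from compound 2 to compound 1 (2.30 log units; beyond the scatter).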

Compound 4, half-maximal inhibitory concentration: > 20000 nM
Compound 4: no number, only a limit; the forecaster's own chance of this, stated with the estimate: 35%; at least 10-fold (1.00 log units) between middle value and limit.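

In this assay compound 4 gives only a limit, > 20000 nM. Within the data shown here, compound 3 stands at that limit too, so no step between compound 3 and compound 4 can be read. The compounds shown leave open whether furan-3-yl in place of thiophen-2-yl changes anything on this core.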